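Trading a sulfanyl chain end for isopropylcarbamoyl

The source may hold more compounds than are shown below. What is called first, only, known or untested is meant among the compounds shown, and "the series" means these compounds.

In a functional assay (trachea) with Cavia porcellus as the target (a higher number here means a weaker inhibitor, a lower number a stronger inhibitor), compound 1 `O=c1c2ccccc2c(-c2cccnc2)nn1CCSc1nccs1` gives 10500 nM and compound 2 `O=c1c2ccccc2c(-c2cccnc2)nn1CCCCSc1ncccn1` gives 6170 nM. Going by the values given here, compound 2 therefore stands within the scatter of its only neighbour, and the single measured step is a 1.7-fold lower number from compound 1 to compound 2 (0.23 log units; within the scatter). Compound 3 `CC(C)NC(=O)CCCn1nc(-c2cccnc2)c2ccccc2c1=O` keeps the shared core but changes the chain: isopropylcarbamoyl in place of ((pyrimidin-2-yl)sulfanyl)methyl on a saturated chain carbon, three bonds along the chain from an aromatic nitrogen. Among the compounds with values here, the measured step exchanged one sulfanyl-bearing chain for another, so it bears on this change only weakly, and no measured compound carries isopropylcarbamoyl. The data therefore offer no ground for a direction, and no shift beyond the scatter is expected in this assay, with compound 2 at 6170 nM as the anchor. The estimated change is a 1.2-fold higher number from compound 2 to compound 3 (0.08 log units; within the scatter). For compound 3 the estimated value is 7500 nM, with an expected range from 2000 nM to 28000 nM.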

Compound 3, half-maximal inhibitory concentration: 64600 nM
Beside the measured number, compound 3's estimate is 8.6-fold (0.94 log units) below it; the whole stated range lies below it.
By their numbers in this assay, from the lowest: compounds 2 and 1 (each within the scatter of the next); then compound 3.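

In this assay, going by these compounds alone, the chain end proves far less tolerant than the earlier compounds suggested: the exchange of one sulfanyl-bearing chain for another stayed within the scatter, yet isopropylcarbamoyl in place of ((pyrimidin-2-yl)sulfanyl)methyl gives a 10-fold higher number from compound 2 to compound 3 (1.02 log units; beyond the scatter) and counts as a large step. The comparison with the other sulfanyl-bearing chain points the same way, with a 6.2-fold higher number from compound 1 to compound 3 (0.79 log units; beyond the scatter) as a modest step, so in both listed comparisons the isopropylcarbamoyl chain gives the weaker inhibitor. Nothing on hand accounts for this loss.

The compounds shown leave open whether the loss goes with the carbamoyl group itself or with the absence of any ring at the chain end. A carboxylic acid, an unsubstituted carbamoyl or a longer chain carrying isopropylcarbamoyl at this place could begin to separate those readings.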